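This account rests on a few compounds, and the source may have more. Where it says the series, first, only, none or still open, it means among the compounds named here.

Compound 1 `O=C(CCSc1nnc(-c2ccncc2)s1)Nc1ccc(Cl)cc1Cl` — in an ADME assay on HepG2 cells (Homo sapiens) for cytotoxicity, with a stated time of 3 days (a higher number here means that more compound is tolerated, a lower number that less compound is tolerated), compound 1 gives > 50000 nM, which is a limit of the assay and not a number.
Compound 2 `CC(CSc1nnc(-c2ccncc2)s1)C(=O)Nc1ccc(Cl)cc1Cl` — in this assay compound 2 gives > 50000 nM, again a limit rather than a number.

Compound 1 therefore stands at the ceiling of this assay, and so does every value shown, as the limit of > 50000 nM in this assay, at which 2 of the 2 values shown sit, makes plain. Within the data shown here, the only step measured within this pair, a step that the two limits leave unreadable from compound 1 to compound 2, is left unreadable by the two limits, so nothing about its size or direction can be drawn from it. The unmeasured compound 3 `O=C(CCSc1nnc(-c2ccncc2)s1)NCc1ccc(Cl)cc1` differs from compound 1 at the amide-type nitrogen: 4-chlorobenzyl in place of 2,4-dichlorophenyl on an amide-type nitrogen. Among the measured compounds shown here, no measured step touches this change, and the one step at hand says nothing about size. Because every value shown sits at the limit of > 50000 nM in this assay, at which 2 of the 2 values shown sit, compound 3 is expected to remain at that limit as well, and the estimate for compound 3 in this assay is 50000 nM, reaching from 20000 nM to 120000 nM. The step this implies, a number no higher from compound 1 to compound 3 (the limit leaves the size open), is expected to be none beyond the usual scatter.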

Compound 3, half-maximal cytotoxic concentration: 15600 nM
Compound 3: the middle estimate sits 3.2-fold (0.51 log units) above what was measured; the whole stated range lies above it.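

Moving from 2,4-dichlorophenyl to 4-chlorobenzyl on the amide-type nitrogen gives an at least 3.2-fold lower number from compound 1 to compound 3 (0.50 log units; beyond the scatter), which shows that the read-out in this assay responds to a change at this position. Among these compounds, the methyl on the saturated chain carbon could not show this, as the step from compound 1 to compound 2 lies between two limits and cannot be read, so this is the first change in the set whose direction is clear. Its full size remains unknown, and compound 3 alone has left the ceiling of the assay: the limit of > 50000 nM in this assay, at which 2 of the 3 values shown sit.

The change alters the carbon and chlorine counts together, so the compounds shown do not separate the loss of one chlorine from the gain of one carbon; 4-chlorophenyl or 2,4-dichlorobenzyl on the same nitrogen would divide the two effects. Also open, as far as these compounds go, is whether a longer chain on that nitrogen, or an amine in place of the chlorine of the 4-chlorobenzyl group, would lower the number further or return it to the limit.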